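Methyl on a Different Ring of a Different Core

The compounds below may be only part of what the source reports. "The series", "measured", "known", "first", "only" and "open" are said of these compounds alone.

Compound 1 `COC(=O)[C@@]1(C)CCC=C2[C@@H]1CC[C@@H](C)[C@]2(C)Cc1c[nH]c2c(Br)cccc12`: 13000 nM
Compound 2 `COC(=O)[C@@]1(C)CCC=C2[C@@H]1CC[C@@H](C)[C@]2(C)Cc1c(C)[nH]c2c(Br)cccc12`: 22000 nM
Compound 3 `COC(=O)[C@@]1(C)CC[C@@H]2C3=C1CC[C@@H](C)[C@]3(C)Cc1c2[nH]c2ccccc12`: 3200 nM

Three compounds have been run in a functional assay on HeLa cells (Homo sapiens) for inhibition, read by sulforhodamine B assay, with a stated time of 48 h; on this read-out higher numbers stand for weaker inhibition of growth and lower numbers for stronger inhibition of growth. Compound 1 gives 13000 nM. Compound 2 differs from it by methyl in place of hydrogen on an aromatic carbon and gives 22000 nM, so that a 1.7-fold higher number from compound 1 to compound 2 (0.23 log units; within the scatter). Compound 3 rests on a different core; the difference between the two cores is not broken down here. In this assay compound 3 gives 3200 nM, the lowest of the three numbers, and its distance from each of the other two lies beyond the usual scatter.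

Compound 4 `COC(=O)[C@@]1(C)CC[C@@H]2C3=C1CC[C@@H](C)[C@]3(C)Cc1c2[nH]c2ccc(C)cc12` is not yet measured. It differs from compound 3 by methyl in place of hydrogen on an aromatic carbon. This is the same kind of change as that from compound 1 to compound 2, but the place is not the same: in compound 2 the methyl sits on a five-membered aromatic ring with 1 nitrogen, part of a fused or bridged system of two rings, next to the ring nitrogen and next to the ring atom that bears a large group, whereas in compound 4 it sits on a six-membered aromatic ring of carbon only, part of a fused or bridged system of five rings, meta to a fused ring and para to a fused ring.

Among the compounds with values here, the only earlier instance of this kind of change is small, a 1.7-fold higher number from compound 1 to compound 2 (0.23 log units; within the scatter). Because that instance gives a 1.7-fold higher number from compound 1 to compound 2 (0.23 log units; within the scatter), a step of similar size, a 1.4-fold higher number from compound 3 to compound 4 (0.15 log units; within the scatter), is expected for compound 4. Compound 4 is therefore estimated at 4500 nM, most likely between 1800 nM and 11000 nM.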

Compound 4, concentration for 50% growth inhibition: 11000 nM
Estimate against measurement, compound 4: 2.4-fold (0.39 log units) below; the range from low to high includes it.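

On the core of compound 3, methyl in place of hydrogen on an aromatic carbon gives a 3.4-fold higher number from compound 3 to compound 4 (0.54 log units; beyond the scatter) in this assay, so here the change goes with weaker inhibition of growth. Within the data shown here, this does not show that the step carries over unchanged from one core to the other: the methyl sits on a five-membered aromatic ring with 1 nitrogen in compound 2 and on a six-membered aromatic ring of carbon only in compound 4, so core and place differ together, and only one pair stands on each core. Within these limits, the two steps cannot be told apart, although only the second lies beyond the scatter when read on its own: the same change on two cores in this assay, a 1.7-fold higher number (0.23 log units; within the scatter) from compound 1 to compound 2 and a 3.4-fold higher number (0.54 log units; beyond the scatter) from compound 3 to compound 4, 2.0-fold (0.31 log units) apart, within the scatter of two such steps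

The compounds shown leave open how the number would respond to a group other than methyl on the same six-membered aromatic ring, such as a hydroxyl, an amine or a longer chain like ethyl, and whether any of these would stay as close as compound 3 at 3200 nM. They also leave open what a carboxylic acid in place of the methyl ester would do on either core.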